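The source may hold more compounds than are shown below. What is called first, only, known or untested is meant among the compounds shown, and "the series" means these compounds.

Measured compounds:
- Compound 1, `O=C(Nc1ccc(Oc2ccnc3[nH]ccc23)cc1)c1cc2cccnc2n(-c2ccc(F)cc2)c1=O`; in a functional assay on HT-29 cells (Homo sapiens) for antiproliferative activity, read by MTT assay, with a stated time of 72 h (a higher number here means a weaker inhibitor, a lower number a stronger inhibitor), compound 1 gives 160 nM.
- Compound 2, `O=C(Nc1ccc(Oc2ccnc3[nH]ccc23)c(F)c1)c1cc2cccnc2n(-c2ccc(C(F)(F)F)cc2Cl)c1=O`; in this assay compound 2 gives 1360 nM.
- Compound 3, `Cn1ccc2c(Oc3ccc(NC(=O)c4cc5cccnc5n(-c5ccc(F)cc5)c4=O)cc3)ccnc21`; in this assay compound 3 gives 250 nM.

Compound 3 stands second highest of the three numbers. Its nearest neighbour is compound 1, and the step of a 1.6-fold higher number from compound 1 to compound 3 (0.19 log units; within the scatter) falls within the scatter, so the two cannot be told apart. For the measured compounds named here, compound 2 sits furthest away with a clearly higher number, but it differs from the others in two places at once, so no single step can be drawn from it.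

Compound 4, `Cn1ccc2c(Oc3ccc(NC(=O)c4cc5cccnc5n(-c5ccc(Br)cc5F)c4=O)cc3)ccnc21`, is not yet measured. Compared with compound 3 the change is 4-bromo-2-fluorophenyl in place of 4-fluorophenyl on an aromatic nitrogen. Going by the values given here, the only single step available, a 1.6-fold higher number from compound 1 to compound 3 (0.19 log units; within the scatter), concerns the methyl on a different nitrogen and says nothing about the group on this one. The pair of compounds 1 and 2 shows that a more heavily substituted group here came with a higher number, yet a second change sits in that pair as well. On that thin basis a modest rise is expected, a 2.0-fold higher number from compound 3 to compound 4 (0.30 log units; within the scatter), and compound 4 is estimated at 500 nM, in the range 150 nM to 1700 nM.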

Compound 4, half-maximal inhibitory concentration: 2580 nM
For compound 4 the middle estimate is 5.2-fold (0.71 log units) below the measured one; measured number above the stated range.
By their numbers in this assay, from the lowest: compounds 1 and 3 (each within the scatter of the next); then compounds 2 and 4 (each within the scatter of the next).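

In this assay, the group on this aromatic nitrogen proves able to move the number a long way: with the rest of the molecule unchanged, 4-bromo-2-fluorophenyl in place of 4-fluorophenyl gives a 10-fold higher number from compound 3 to compound 4 (1.01 log units; beyond the scatter). For the compounds shown here, this is the first view of this position through a single change, as the pair of compound 1 and compound 2 carried a second change elsewhere, and it contrasts with the methyl change on the other nitrogen, which gave a 1.6-fold higher number from compound 1 to compound 3 (0.19 log units; within the scatter). Nothing in the data at hand explains why the number rose.

The compounds shown leave open whether the bromine or the added fluorine carries this step, as the two enter together in a single change. They also leave open how a phenyl group bearing an amine or a carboxylic acid, or a short alkyl chain in place of the phenyl group, would read in this assay.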